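A few compounds are considered here, and "the series" means these few. Any claim that something is new, unique, unknown or untested is made for them only; others in the source may bear on it.

Of the compounds shown here, three built on one shared core have been measured in a toxicity assay on MT4 cells (Homo sapiens) for cytotoxicity, read by MTT assay; on this read-out higher numbers stand for lower toxicity in this test and lower numbers for higher toxicity in this test. Compound 1 `Cc1cccc(-c2cc(C)c(Oc3cc(N)nc(Nc4ccc(C#N)cc4)n3)c(C)c2)c1` gives 27600 nM, compound 2 `COc1cccc(-c2cc(C)c(Oc3cc(N)nc(Nc4ccc(C#N)cc4)n3)c(C)c2)c1` gives 19300 nM, and compound 3 `COc1ccc(-c2cc(C)c(Oc3cc(N)nc(Nc4ccc(C#N)cc4)n3)c(C)c2)cc1` gives 10700 nM. Compound 3 thus sits under compound 1 and level with compound 2. The data show a 2.6-fold lower number from compound 1 to compound 3 (0.41 log units; beyond the scatter), whereas they show a 1.8-fold lower number from compound 2 to compound 3 (0.26 log units; within the scatter).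

Compound 4 `Cc1cc(-c2ccccc2C#N)cc(C)c1Oc1cc(N)nc(Nc2ccc(C#N)cc2)n1` has not yet been measured. It carries 2-cyanophenyl in place of 4-methoxyphenyl on an aromatic carbon. The two steps above bear on this change, since each also swaps the aryl group at that place, and so does a 1.4-fold lower number from compound 1 to compound 2 (0.16 log units; within the scatter). Across these swaps, the largest movement was only modest and the other two stayed within the scatter. Within the data shown here, none of the measured compounds carries a nitrile on that ring, so the direction of the change is poorly defined.

No step beyond the scatter is therefore expected in this assay, with a slight upward drift towards the values of the other two compounds the likelier outcome. The expected change is a 1.4-fold higher number from compound 3 to compound 4 (0.15 log units; within the scatter). For compound 4 the estimated value is 15000 nM, with an expected range from 6000 nM to 38000 nM.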

Compound 4, half-maximal cytotoxic concentration: 25400 nM
Compound 4: middle estimate off by 1.7-fold (0.23 log units), on the low side; the range from low to high includes it.
By their numbers in this assay, from the lowest: compounds 3, 2, 4 and 1 (each within the scatter of the next, the first and the last beyond it).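

In this assay, the step to a ring bearing a nitrile, the first such ring at this place, is a 2.4-fold higher number from compound 3 to compound 4 (0.38 log units; beyond the scatter), which is modest but beyond the scatter. The same group stands level with the other two aryl groups, with a 1.3-fold higher number from compound 2 to compound 4 (0.12 log units; within the scatter) and a 1.1-fold lower number from compound 1 to compound 4 (0.04 log units; within the scatter), both within the scatter, so swapping 3-methylphenyl or 3-methoxyphenyl for 2-cyanophenyl leaves the number where it was. Among the four compounds, only 4-methoxyphenyl stands apart from any other group at this place, and it does so from compound 1 and compound 4 but not from compound 2, so the low number of compound 3 now looks tied to that one group rather than to aryl swaps here in general.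

The compounds shown leave open whether the nitrile would give the same number elsewhere on that ring, and how an amine or a carboxylic acid on that ring would read in this assay. No measurement given alongside these numbers accounts for the step from 4-methoxyphenyl to 2-cyanophenyl.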